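From methoxy to hydroxy in a growth-inhibition test

The source may report more compounds than this note shows. Statements on the series, on what has been measured and on what is new or still open speak of the compounds shown alone.

Compound 1 `CO/N=C/C=C/c1ccccc1OC(=O)c1ccccc1`: > 100000 nM (a limit of the assay, not a number)
Compound 2 `COc1ccccc1/C=C/C(=O)NO`: 26900 nM
Compound 3 `CN1CCN(C(=O)ONC(=O)/C=C/c2ccccc2OC(=O)c2ccccc2)CC1`: 45200 nM

All three compounds were tested in a functional assay on NCI-H23 cells (Homo sapiens) for inhibition, read by ELISA, with a stated time of 24 h; on this read-out lower numbers stand for stronger inhibition of growth and higher numbers for weaker inhibition of growth. Only compound 2 and compound 3 give true numbers, and these lie within the usual scatter of each other, so neither can be ranked ahead of the other. Compound 2 therefore stands level with compound 3 on these data.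

Compound 4 `O=C(/C=C/c1ccccc1O)NO` differs from compound 2 in one place, methoxy to hydroxy, with hydrogen in place of methyl on an oxygen on an aromatic ring. For the measured compounds named here, no pair of measured compounds shows this change, so the expectation rests on compound 2 at 26900 nM alone. The data give no firm direction, and no shift beyond the scatter is expected in this assay. The expected change is a 1.2-fold lower number from compound 2 to compound 4 (0.09 log units; within the scatter). For compound 4 the estimate is 22000 nM, with an expected range of 8000 nM to 60000 nM.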

Compound 4, concentration for 50% growth inhibition: 27800 nM
Beside the measured number, compound 4's estimate is 1.3-fold (0.10 log units) below it; the range from low to high includes it.
By their numbers in this assay, from the lowest: compounds 2, 4 and 3 (each within the scatter of the next). At a limit, above all of these: compound 1.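

In this assay, this is the only pair shown that differs in one place, and hydrogen in place of methyl on an oxygen on an aromatic ring gives a 1.0-fold higher number from compound 2 to compound 4 (0.01 log units; within the scatter). For the compounds shown here, at this position, then, methoxy and hydroxy cannot be told apart on this read-out, something the earlier compounds, with no step between them, could not show. The step joins two true numbers, and the only limit among the values shown belongs to compound 1: the limit of > 100000 nM in this assay, at which 1 of the 4 values shown sits.

Going by these compounds, it remains open whether a longer alkyl chain on this oxygen, or an amine in its place, would move the number beyond the scatter. On these data alone, it also remains open whether methoxy to hydroxy would behave the same way on another core.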